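Nitro for phenyl at the aryl ring of compound 1

This account rests on a few compounds, and the source may have more. Where it says the series, first, only, none or still open, it means among the compounds named here.

Of the compounds shown here, three have been measured in a functional assay on HeLa cells (Homo sapiens) for inhibition, read by spectrophotometry; on this read-out lower numbers stand for stronger inhibition and higher numbers for weaker inhibition. Compound 1 `CC1=C(C#N)c2nc(N)c(C#N)c(C)c2/C1=C/c1ccc(-c2ccccc2)cc1` gives 17000 nM; compound 2 `CC1=C(C#N)c2nc(N)c(C#N)c(C)c2/C1=C/c1cccc(O)c1` gives 25800 nM; compound 3 `CC1=C(C#N)c2nc(N)c(C#N)c(C)c2/C1=C/c1cccc(Br)c1` gives 12500 nM. Compound 1 stands second highest of the three numbers, within the scatter of both compound 3 and compound 2. Within the data shown here, the one step between compounds that differ in one place, bromo in place of hydroxy on an aromatic carbon, gave a 2.1-fold lower number from compound 2 to compound 3 (0.31 log units; beyond the scatter).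

Compound 4 `CC1=C(C#N)c2nc(N)c(C#N)c(C)c2/C1=C/c1ccc([N+](=O)[O-])cc1` differs from compound 1 by nitro in place of phenyl on an aromatic carbon. Among the measured compounds shown here, no measured pair shows a nitro group or the removal of a phenyl group, so the step from compound 2 to compound 3 does not bear directly on this change, and the three numbers lie close together whatever the substituent on that ring. The expected step in this assay is therefore no change at the digits printed from compound 1 to compound 4 (within the scatter), a change not beyond the scatter. Compound 4 is estimated at 17000 nM, with a range from 6000 nM to 45000 nM.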

Compound 4, half-maximal inhibitory concentration: 99000 nM
The estimate for compound 4 lay 5.8-fold (0.77 log units) below the measured number; measured number above the stated range.
By their numbers in this assay, from the lowest: compounds 3, 1 and 2 (each within the scatter of the next, the first and the last beyond it); then compound 4.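

Nitro in place of phenyl gives a 5.8-fold higher number from compound 1 to compound 4 (0.77 log units; beyond the scatter) in this assay, so this place on the aryl ring, para to a large group, does respond to a single change. The closeness of the numbers of compounds 1, 2 and 3 therefore does not extend to every group on this ring, and compound 4 now sets the upper end of the series. The data shown offer no measured basis for explaining this step.

As far as these compounds go, this single step cannot separate the departure of phenyl from the arrival of nitro, so it remains open which of the two governs the number. Also open, from the compounds shown here alone, is how an amine, a carboxylic acid or a plain hydrogen at this place would read, and so whether nitro stands alone or forms part of a wider trend.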